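The source may hold more compounds than are shown below. What is called first, only, known or untested is meant among the compounds shown, and "the series" means these compounds.

Measured so far in a functional assay on PRK cells (Oryctolagus cuniculus) for cytotoxicity; on this read-out lower numbers stand for higher toxicity in this test and higher numbers for lower toxicity in this test:
compound 1 `CCCCCCCCOC(=O)C(O)Cn1cnc2c(N)ncnc21` gives 100 ug/mL
compound 2 `CCCOC(=O)C(O)Cn1cnc2c(N)ncnc21` gives 100 ug/mL

Compound 2 stands level with compound 1 at the digits shown; the only measured step, no change at the digits printed from compound 1 to compound 2 (within the scatter), shortened the ester chain from octyl to propyl and produced nothing beyond the scatter. The next compound to be tested is compound 3 `CC(C)CCOC(=O)C(O)Cn1cnc2c(N)ncnc21`. The change from compound 2 is isopropyl in place of methyl on a saturated chain carbon, two bonds along the chain from an oxygen next to a carbonyl group. Within the data shown here, this touches the same ester chain as the one measured step: compound 3 carries an isopentyl chain, longer than the propyl of compound 2 and shorter than the octyl of compound 1, and branched where both of those are straight. Branching on this chain has no measured precedent in the series, so only chain length can be judged, and over the full span from propyl to octyl the step of no change at the digits printed from compound 1 to compound 2 (within the scatter) was flat. No step beyond the scatter is therefore expected in this assay, and no change at the digits printed from compound 2 to compound 3 (within the scatter) is estimated as essentially flat. Compound 3 is expected to give 100 ug/mL, with a range from 50 ug/mL to 200 ug/mL.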

Compound 3, minimum cytotoxic concentration: 400 ug/mL
Estimate against measurement, compound 3: 4.0-fold (0.60 log units) below, and the stated range ends below it.
By their numbers in this assay, from the lowest: compounds 1 and 2 (each within the scatter of the next); then compound 3.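

In this assay, the ester chain is not a silent position after all: isopropyl in place of methyl on a saturated chain carbon, two bonds along the chain from an oxygen next to a carbonyl group, gives a 4.0-fold higher number from compound 2 to compound 3 (0.60 log units; beyond the scatter), and on this read-out the higher number stands for lower toxicity in this test. The same isopentyl chain gives a 4.0-fold higher number from compound 1 to compound 3 (0.60 log units; beyond the scatter), so compound 3 stands apart from both straight-chain esters, even though its chain is intermediate in length between the propyl of compound 2 and the octyl of compound 1, which show no change at the digits printed from compound 1 to compound 2 (within the scatter). No measurement in hand accounts for this shift.

Among these three compounds, branching and chain length are not separated, since compound 3 is the only branched ester and the only one with an isopentyl chain, so a straight pentyl ester would show whether the higher number goes with the branch or with this chain length. As far as these compounds go, whether another branched ester, such as isobutyl or a longer chain with the same terminal isopropyl, keeps the higher number also stays open.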